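Dimethylamino for fluoro on a stilbene sulfonamide: expected growth inhibition

A few compounds are considered here, and "the series" means these few. Any claim that something is new, unique, unknown or untested is made for them only; others in the source may bear on it.

Of the compounds shown here, three sharing a stilbene sulfonamide core have been measured in a functional assay on OVCAR-4 cells (Homo sapiens) for inhibition; a lower number here means a stronger inhibitor of growth, a higher number a weaker inhibitor of growth. Compound 1 `COc1cc(/C=C/c2ccc(S(N)(=O)=O)cc2)cc(OC)c1` gives 21200 nM, compound 2 `COc1cccc(/C=C/c2ccc(S(N)(=O)=O)cc2)c1` gives 25000 nM, and compound 3 `NS(=O)(=O)c1ccc(/C=C/c2ccc(F)cc2)cc1` gives 34400 nM. Compound 3 thus carries the highest of the three numbers, but its gap to compound 2 and to compound 1 lies within the scatter, so the three cannot be told apart.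

Compound 4 `CN(C)c1ccc(/C=C/c2ccc(S(N)(=O)=O)cc2)cc1` differs from compound 3 in one place: dimethylamino in place of fluoro on an aromatic carbon. Among the compounds with values here, the only measured single-point step is hydrogen in place of methoxy on an aromatic carbon, and a 1.2-fold higher number from compound 1 to compound 2 (0.07 log units; within the scatter) is itself within the scatter. Within the data shown here, no measured step touches the fluoro position or brings in a dimethylamino group, so nothing directly bears on this change.

Among the measured compounds shown here, with the one measured substituent change showing no real movement, and all three compounds clustering at weak inhibition in this assay, a step of modest size at most is expected; the direction cannot be anchored to a measured step. Compound 4 is therefore estimated at 22000 nM, within a range of 6000 nM to 80000 nM, a step of a 1.6-fold lower number from compound 3 to compound 4 (0.19 log units; within the scatter) that is expected to stay close to compound 3.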

Compound 4, concentration for 50% growth inhibition: 3340 nM
Compound 4: middle estimate off by 6.6-fold (0.82 log units), on the high side; measured number outside the range, below it.
By their numbers in this assay, from the lowest: compound 4; then compounds 1, 2 and 3 (each within the scatter of the next).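

In this assay, within the data shown here, dimethylamino in place of fluoro on an aromatic carbon, para to a large group, gives a 10-fold lower number from compound 3 to compound 4 (1.01 log units; beyond the scatter) and is the first single change here to move the number beyond the scatter. Among these compounds, the only earlier step, a 1.2-fold higher number from compound 1 to compound 2 (0.07 log units; within the scatter), stayed within the scatter and involved a different change, so it gave no sign that the group at this position could matter so much. The change replaces one heavy atom with three and adds a hydrogen-bond acceptor, but the compounds do not show whether either difference matters, and no measured evidence explains the size of the step.

On these data alone, it remains open whether the step depends on the nitrogen itself or on the two methyl groups attached to it, a question that a plain amino group or a larger diethylamino group at the same place could help to settle. As far as these compounds go, it is equally open whether a carbon-only group such as isopropyl would produce a similar step, which would show whether the nitrogen is needed at all.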